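A few compounds are considered here, and "the series" means these few. Any claim that something is new, unique, unknown or untested is made for them only; others in the source may bear on it.

Measured compounds:
compound 1, `C[C@H](O)CNc1cc(Oc2ccc(NC(=O)Nc3cccc(C(F)(F)F)c3)cc2)ncn1` — in an assay on isolated protein for inhibition of serine/threonine-protein kinase TNNI3K (Homo sapiens) (on this read-out lower numbers stand for stronger inhibition and higher numbers for weaker inhibition), compound 1 gives 32 nM
compound 2, `O=C(Nc1ccc(Oc2ccncc2)cc1)Nc1cccc(C(F)(F)F)c1` — in this assay compound 2 gives 50 nM

Compound 2 carries the higher of the two numbers recorded in this assay, but its nearest neighbour, compound 1, lies within the usual scatter of it, so the two values cannot be ranked against each other on what is known here.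

Compound 3, `O=C(Nc1ccc(Oc2cc(NCCO)ncn2)cc1)Nc1cccc(C(F)(F)F)c1`, has not yet been measured in this assay. It differs from compound 2 in a single place: 6-((2-hydroxyethyl)amino)pyrimidin-4-yl in place of pyridin-4-yl on an oxygen on an aromatic ring. Among the compounds with values here, the group that enters closely resembles the one compound 1 carries on the same oxygen, the hydroxyethyl chain being one carbon shorter than the hydroxypropyl chain of compound 1.

Within the data shown here, no step between two measured compounds is available to set the size of this change. Because compound 1 gives 32 nM and compound 2 gives 50 nM, the account expects a small step from compound 2 to compound 3, if any, toward a lower number, with a 1.6-fold lower number from compound 2 to compound 3 (0.19 log units; within the scatter) as the expected size. For compound 3 the estimate in this assay is 32 nM, with a range from 12 nM to 90 nM.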

Compound 3, half-maximal inhibitory concentration: 32 nM
The estimate for compound 3 equals the measured number at the digits printed, and the stated range covers the measured number.
By their numbers in this assay, from the lowest: compounds 1, 3 and 2 (each within the scatter of the next).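

In this assay, 6-((2-hydroxyethyl)amino)pyrimidin-4-yl in place of pyridin-4-yl on an oxygen on an aromatic ring gives a 1.6-fold lower number from compound 2 to compound 3 (0.19 log units; within the scatter), so this position accepts the group with more heavy atoms, hydrogen-bond donors and hydrogen-bond acceptors without a difference that can be read. The comparison within the amino side chain gives no change at the digits printed from compound 1 to compound 3 (within the scatter), showing that hydrogen in place of the methyl group of compound 1 leaves the result in this assay within the scatter. Nothing among the available data explains why either exchange leaves the number within the scatter.

What the hydroxyl group contributes stays open, as the compounds shown offer no comparison with a methoxy group, an amine or a carboxylic acid in its place, or with a plain ethylamino group on the pyrimidin-4-yl ring. Also open, on these data alone, is how a longer chain, a morpholine in place of the 2-hydroxyethylamino group, or the mirror-image form of the chain in compound 1 would read in this assay.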